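The compounds below may be only part of what the source reports. "The series", "measured", "known", "first", "only" and "open" are said of these compounds alone.

Measured so far:

Compound 1, `O=C(Nc1ccc(C(F)(F)F)cc1)C1CCc2ccccc2N1`: 25800 nM
Compound 2, `CCCCCCCCC(=O)N1c2ccccc2CCC1C(=O)Nc1ccccc1C(F)(F)F`: 4220 nM
Compound 3, `O=C(Nc1ccc(O)cc1)C1CCc2ccccc2N1`: > 100000 nM

All three were tested in a functional assay on NCI-H23 cells (Homo sapiens) for cytotoxicity, read by sulforhodamine B assay, with a stated time of 72 h; on this read-out higher numbers stand for weaker inhibition of growth and lower numbers for stronger inhibition of growth. In this assay compound 1 gives 25800 nM. Compound 2 gives 4220 nM, the lower of the two numbers, and compound 1 is the nearest to it. For compound 3 the assay reports only a limit, > 100000 nM, and not a number.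

Compound 1 and compound 3 differ in one place: hydroxy in place of trifluoromethyl on an aromatic carbon. That change gave an at least 3.8-fold higher number from compound 1 to compound 3 (0.58 log units; beyond the scatter). The size of this step is known only as a lower bound because of the limit of > 100000 nM in this assay, at which 1 of the 3 values shown sits.

Compound 2 shares the core of compound 1, but the difference between the two cores is not broken down here.

Compound 4, `CCCCCCCCC(=O)N1c2ccccc2CCC1C(=O)Nc1ccccc1O`, has not yet been measured. It differs from compound 2 in one place: hydroxy in place of trifluoromethyl on an aromatic carbon. Among the measured compounds shown here, this is the same kind of change as the one from compound 1 to compound 3, but not the same: there the hydroxy sits para to a large group, here it sits ortho to a large group. The expectation for compound 4 rests on the weakening seen in an at least 3.8-fold higher number from compound 1 to compound 3 (0.58 log units; beyond the scatter); a step of about a 7.1-fold higher number from compound 2 to compound 4 (0.85 log units; beyond the scatter) is expected, with the nearer surroundings of the changed position leaving the size uncertain. On that basis compound 4 is estimated at 30000 nM, likely between 8000 nM and 100000 nM.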

Compound 4, concentration for 50% growth inhibition: 55800 nM
Beside the measured number, compound 4's estimate is 1.9-fold (0.27 log units) below it; the measured number falls inside the stated range.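

In this assay, putting hydroxy in place of trifluoromethyl on the core of compound 2 gave a 13-fold higher number from compound 2 to compound 4 (1.12 log units; beyond the scatter), which means weaker inhibition of growth. The same change also weakened inhibition on the core of compound 1, so the direction of the change carried over in these two pairs, although two pairs do not make a rule for the whole series and the group sits at a different place on the aromatic ring in each pair. Whether the size of the step also carried over cannot be read from these results: the same change on two cores in this assay, an at least 3.8-fold higher number (0.58 log units; beyond the scatter) from compound 1 to compound 3 and a 13-fold higher number (1.12 log units; beyond the scatter) from compound 2 to compound 4; the limit leaves it open whether they differ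

What the compounds shown leave open is whether the different size of the step, if there is one, would come from the place of the group on the aromatic ring or from the long chain that compound 2 and compound 4 carry and compound 1 and compound 3 lack. Also open, as far as these compounds go, is how an amine or a carboxylic acid would behave in the place of trifluoromethyl, and how a shorter chain would behave in the place of the long chain.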